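Adding a Methoxy Group to a Weakly Cytotoxic Series

The source may report more compounds than this note shows. Statements on the series, on what has been measured and on what is new or still open speak of the compounds shown alone.

Three compounds have so far been tested in a functional assay on DU-145 cells (Homo sapiens) for cytotoxicity, read by MTT assay, with a stated time of 48 h; on this read-out higher numbers stand for weaker inhibition and lower numbers for stronger inhibition:

compound 1, `COc1ccc(/C=C/C(=O)/C=C/c2cc3ccccc3nc2Oc2ccccc2)c(OC)c1`, gives a limit of the assay: > 10000 nM
compound 2, `COc1cc(OC)c(/C=C/C(=O)/C=C/c2cc3ccccc3nc2Oc2ccccc2)c(OC)c1`, gives a limit of the assay: > 10000 nM
compound 3, `COc1ccc(/C=C/C(=O)/C=C/c2cc3ccccc3nc2Oc2ccc(Br)cc2)cc1`, gives a limit of the assay: > 10000 nM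

Compound 1 and compound 2 differ in one place, (methoxy in place of hydrogen on an aromatic carbon). The step that the two limits leave unreadable from compound 1 to compound 2 cannot be sized because both values sit at the limit of > 10000 nM in this assay, at which 3 of the 3 values shown sit. Compound 3 shares much of its framework with compound 1, but the difference between the two cores is not broken down here; its value in this assay is also a limit, so it stands with the other two rather than apart from them.

Compound 4, `COc1ccc(/C=C/C(=O)/C=C/c2cc3ccccc3nc2Oc2ccc(Br)cc2)c(OC)c1`, has not yet been measured. It differs from compound 3 by methoxy in place of hydrogen on an aromatic carbon. Among the measured compounds shown here, this is the same kind of change as the one from compound 1 to compound 2, though not the same: here the place is meta to a methoxy group, whereas in the earlier pair it is meta to two methoxy groups. The step from compound 3 to compound 4 is expected to be a step that the limit leaves unreadable from compound 3 to compound 4, resting on compound 3 sitting at the limit of > 10000 nM in this assay, at which 3 of the 3 values shown sit, and on the earlier step being unreadable. Compound 4 is therefore estimated at 15000 nM, with an expected range from 5000 nM to 50000 nM, and most likely a limit again.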

Compound 4, half-maximal inhibitory concentration: > 10000 nM
Compound 4: only a limit was reported; the forecaster's own chance of this, stated with the estimate: 80%; the middle value does not contradict the limit.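

In this assay compound 4 gives > 10000 nM and this is a limit of the assay, not a number. No step from compound 3 or compound 1 to compound 4 can be read, because all the compounds share one limit: the limit of > 10000 nM in this assay, at which 4 of the 4 values shown sit.

The compounds shown leave open whether methoxy or bromo in place of hydrogen changes cytotoxicity at all, and how strong any of the four compounds really is.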